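Replacing the furan-3-yl group of compound 1

A few compounds are considered here, and "the series" means these few. Any claim that something is new, unique, unknown or untested is made for them only; others in the source may bear on it.

In a functional assay on DU-145 cells (Homo sapiens) for cytotoxicity, read by ELISA, with a stated time of 4 days (on this read-out lower numbers stand for stronger inhibition and higher numbers for weaker inhibition), compound 1 `Clc1ccc(-c2cc(-c3ccoc3)cc(-c3ccco3)n2)s1` gives 17200 nM as its reading, compound 2 `Cc1ccc(-c2cc(-c3ccoc3)cc(-c3ccc(Cl)s3)n2)o1` gives 33400 nM as its reading, and compound 3 `Cc1cccc(-c2cc(-c3ccoc3)cc(-c3ccc(Cl)s3)n2)c1` gives 20300 nM as its reading. These numbers all lie within the scatter of one another, so compound 1 cannot be ranked against the other two. Compound 4 `Clc1ccc(-c2cc(-c3ccco3)nc(-c3ccc(Cl)s3)c2)o1` has not yet been measured. It differs from compound 1 at one place, where 5-chlorofuran-2-yl stands in place of furan-3-yl 5-chlorofuran-2-yl in place of furan-3-yl on an aromatic carbon on an aromatic carbon opposite the ring nitrogen.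

The measured steps offer only indirect guidance. They are a 1.9-fold higher number from compound 1 to compound 2 (0.29 log units; within the scatter) for methyl in place of hydrogen, a 1.2-fold higher number from compound 1 to compound 3 (0.07 log units; within the scatter) for 3-methylphenyl in place of furan-2-yl, and a 1.6-fold lower number from compound 2 to compound 3 (0.22 log units; within the scatter) for 3-methylphenyl in place of 5-methylfuran-2-yl. Compounds 1, 2 and 3 all carry furan-3-yl opposite the ring nitrogen, so the data hold no measured change at that place. No step beyond the scatter is therefore expected in this assay, and neither direction is favoured. An estimated step of a 1.1-fold lower number from compound 1 to compound 4 (0.06 log units; within the scatter) is the expectation. Compound 4 is estimated at 15000 nM with an expected range of 5000 nM to 40000 nM as its bounds.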

Compound 4, half-maximal inhibitory concentration: 27700 nM
Beside the measured number, compound 4's estimate is 1.8-fold (0.27 log units) below it; the measured number falls inside the stated range.
By their numbers in this assay, from the lowest: compounds 1, 3, 4 and 2 (each within the scatter of the next).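

For the compounds shown here, compound 4 gives the first reading for a change at the aromatic carbon opposite the ring nitrogen, a place that held furan-3-yl in all the earlier compounds. In this assay, 5-chlorofuran-2-yl in place of furan-3-yl gives a 1.6-fold higher number from compound 1 to compound 4 (0.21 log units; within the scatter), so this exchange, which brings in a chlorine and changes how the furan is attached, leaves the reading within the scatter of compound 1 and shows that this position can carry a chlorinated furan without a step beyond the scatter. No accompanying measurement bears on this result, and the reading itself gives no explanation for it.

Since the chlorine and the change in furan attachment arrive together in this single step, the compounds shown cannot separate what each contributes, and a plain furan-2-yl or a 5-methylfuran-2-yl at this place would be needed to do so. Going by these compounds alone, all the groups seen at this position so far are furans, so it remains open whether an amine, a carboxylic acid or a longer alkyl chain there would shift the reading beyond the scatter in either direction.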